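A few compounds are considered here, and "the series" means these few. Any claim that something is new, unique, unknown or untested is made for them only; others in the source may bear on it.

For the measured compounds named here, in a functional assay on DU-145 cells (Homo sapiens) for inhibition, read by trypan blue exclusion, with a stated time of 72 h (on this read-out higher numbers stand for weaker inhibition and lower numbers for stronger inhibition), compound 1 `Cn1c(=O)c(S(=O)(=O)c2ccc(F)cc2F)cc2cnc(Nc3ccncn3)nc21` gives 50000 nM, the highest of the three numbers measured so far and therefore the weakest inhibition. Compound 3 `O=c1[nH]c2nc(Nc3ccc4[nH]ccc4c3)ncc2cc1S(=O)(=O)c1ccc(F)cc1F` gives 15000 nM, and compound 2 `COc1ccc(S(=O)(=O)c2cc3cnc(Nc4cccc5[nH]ccc45)nc3n(C)c2=O)cc1` gives 5000 nM. Both of these numbers lie lower than that of compound 1 by more than the usual scatter.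

Compound 4 `Cn1c(=O)c(S(=O)(=O)c2ccc(F)cc2F)cc2cnc(Nc3cnc4[nH]ccc4c3)nc21` keeps the rest of compound 1 and changes one group: a group of 9 heavy atoms (7 carbon, 2 nitrogen; one five-membered aromatic ring with 1 hetero atom, one six-membered aromatic ring with 1 hetero atom) in place of a group of 6 heavy atoms (4 carbon, 2 nitrogen; one six-membered aromatic ring with 2 hetero atoms), on a nitrogen on an aromatic ring. Going by the values given here, no measured pair differs at this place alone, so the size of this step cannot be read directly. The only hint is indirect: compound 3 at 15000 nM and compound 2 at 5000 nM both carry a two-ring group on that nitrogen, though they also differ from compound 1 elsewhere. A moderate move towards stronger inhibition is thus expected, and the estimated step is a 5.0-fold lower number from compound 1 to compound 4 (0.70 log units; beyond the scatter). For compound 4 the expected value is 10000 nM, with an estimated range from 3000 nM to 35000 nM.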

Compound 4, half-maximal inhibitory concentration: 750 nM
Compound 4: the middle estimate sits 13-fold (1.12 log units) above what was measured; the measured number lies below the stated range.
By their numbers in this assay, from the lowest: compound 4; then compound 2; then compound 3; then compound 1.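

In this assay, replacing pyrimidin-4-yl with the two-ring group on this nitrogen gives a 67-fold lower number from compound 1 to compound 4 (1.82 log units; beyond the scatter) while the rest of the molecule stays the same. For the compounds shown here, this is the first direct reading at this position, and it shows that this one change can shift the number by a large step. The data at hand offer no measurement that explains why the step is so large.

The entering group differs from pyrimidin-4-yl at once in size, ring count, and hydrogen-bond donor and acceptor counts, so this single step cannot show which of these differences matters. As far as these compounds go, it also remains open how a plain phenyl or a single pyridine ring on the same nitrogen would compare with these two groups.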